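Toward Compound 4: A New Aryl on the Sulfonyl

This account rests on a few compounds, and the source may have more. Where it says the series, first, only, none or still open, it means among the compounds named here.

Compound 1, `COc1cc2nc(N3CCN(C(=O)OCc4ccccc4)CC3)nc(N)c2cc1OC`: 63000 nM
Compound 2, `COc1cc2nc(N3CCN(C(=O)c4cccc5ccccc45)CC3)nc(N)c2cc1OC`: 59000 nM
Compound 3, `COc1cc2nc(N3CCN(S(=O)(=O)c4ccc(C)cc4)CC3)nc(N)c2cc1OC`: 30000 nM

All three were tested in a functional assay on PC-3 cells (Homo sapiens) for inhibition; on this read-out lower numbers stand for stronger inhibition and higher numbers for weaker inhibition. Compound 3 sits at the low end of the three numbers, though its value and that of compound 2 cannot be told apart within the scatter; against compound 1 the step is a 2.1-fold lower number from compound 1 to compound 3 (0.32 log units; beyond the scatter).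

Compound 4, `COc1cc2nc(N3CCN(S(=O)(=O)c4ccc(N)cc4N)CC3)nc(N)c2cc1OC`, differs from compound 3 by 2,4-diaminophenyl in place of 4-methylphenyl on a sulfonyl sulfur. Among the measured compounds shown here, no measured step changes the group attached to a sulfonyl sulfur. The nearest guides are a 1.1-fold lower number from compound 1 to compound 2 (0.03 log units; within the scatter), where swapping the aryl on a carbonyl carbon changed little, and a 2.1-fold lower number from compound 1 to compound 3 (0.32 log units; beyond the scatter), which introduced the sulfonyl itself. A step within the scatter is therefore expected, a 1.2-fold higher number from compound 3 to compound 4 (0.07 log units; within the scatter). Compound 4 is estimated at 35000 nM, with a range from 12000 nM to 100000 nM.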

Compound 4, half-maximal inhibitory concentration: 67000 nM
For compound 4 the middle estimate is 1.9-fold (0.28 log units) below the measured one, within the range that was stated.
By their numbers in this assay, from the lowest: compounds 3, 2, 1 and 4 (each within the scatter of the next, the first and the last beyond it).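

Replacing 4-methylphenyl with 2,4-diaminophenyl on the sulfonyl sulfur gives a 2.2-fold higher number from compound 3 to compound 4 (0.35 log units; beyond the scatter). The group at this place can therefore shift the number beyond the scatter, here toward weaker inhibition, whereas the aryl swap on the carbonyl carbon did not. Nothing measured here gives a reason for this shift.

From the compounds shown here alone, whether both amines are needed for the shift stays open. So does how 4-aminophenyl, with a single amine, or 4-methoxyphenyl would read on the same sulfonyl sulfur.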